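Two-substituent switch on the benzyl ring of compound 3

The compounds below may be only part of what the source reports. "The series", "measured", "known", "first", "only" and "open" are said of these compounds alone.

Measured compounds:
- compound 1, `COc1ccc2c(c1)CCC(Cc1ccccc1C(F)(F)F)C2=O`, 5340 nM
- compound 2, `CCc1ccccc1CC1CCc2cc(OC)ccc2C1=O`, 8230 nM

Both were run in an assay on CHO cells for inhibition of sterol 26-hydroxylase, mitochondrial (Homo sapiens); a lower number here means a stronger inhibitor, a higher number a weaker inhibitor. Compound 2 holds the higher of the two numbers shown, but its nearest neighbour is compound 1, and the only measured step, a 1.5-fold higher number from compound 1 to compound 2 (0.19 log units; within the scatter), is within the scatter, so nothing separates the two in this assay.

The next compound, compound 3, `COc1ccc2c(c1)CCC(Cc1ccccc1Br)C2=O`, is reached from compound 2 by a single change: bromo in place of ethyl on an aromatic carbon. Among the measured compounds shown here, no measured step exchanges bromo for ethyl, so the one bearing on this change is the trifluoromethyl-to-ethyl step from compound 1 to compound 2, which was within the scatter. With two groups at the same carbon giving indistinguishable numbers, a third group at that carbon is expected to stay close as well. For compound 3 the estimate in this assay is 6000 nM, ranging from 2500 nM to 15000 nM. The expected step of a 1.4-fold lower number from compound 2 to compound 3 (0.14 log units; within the scatter) is therefore not beyond the scatter.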

Compound 3, half-maximal inhibitory concentration: 59 nM
The estimate for compound 3 lay 100-fold (2.01 log units) above the measured number, outside the stated range (below it).
By their numbers in this assay, from the lowest: compound 3; then compounds 1 and 2 (each within the scatter of the next).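

In this assay this aromatic carbon proves highly sensitive to the choice of substituent: bromo in place of ethyl gives a 140-fold lower number from compound 2 to compound 3 (2.14 log units; beyond the scatter) and bromo in place of trifluoromethyl gives a 91-fold lower number from compound 1 to compound 3 (1.96 log units; beyond the scatter) with the rest of the structure unchanged. The earlier pair gave no sign of this, since ethyl and trifluoromethyl could not be told apart, so their agreement does not extend to every group at this carbon and the two now stand together, well separated from bromo. No supporting data accompany these numbers, so the large difference in favour of bromo remains an observation without an explanation.

The three compounds leave open whether the low number belongs to bromo alone or is shared more widely, a question that chloro or iodo at the same carbon would address, with methoxy or nitrile there testing groups of a different kind. Also open, going by these compounds, is whether bromo keeps this effect when it sits on another carbon of the same ring, or whether the effect belongs to this one carbon only.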